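The compounds below may be only part of what the source reports. "The series", "measured", "known", "first", "only" and "open" are said of these compounds alone.

Series notes. The shared core of compound 1 `CCC(C)(C)Cc1c[nH]c(CCc2ccc(-n3ncnn3)cc2)n1` carries a terminal ring group that is exchanged across the set. In a functional assay on HEK293 cells for agonist activity at Bombesin receptor subtype-3 (Mus musculus), read by luminescence and calcium flux, with a stated time of 10 min (on this read-out lower numbers stand for an effect already at smaller amounts and higher numbers for an effect only at larger amounts of compound), compound 1 gives 99 nM. Compound 2 `CCC(C)(C)Cc1c[nH]c(CCc2ccc(-n3ccnn3)cc2)n1` gives 111 nM in this assay, and compound 3 `CCC(C)(C)Cc1c[nH]c(CCc2ccc(-c3cnccn3)cc2)n1` gives 107 nM. The three numbers sit together: a 1.1-fold higher number from compound 1 to compound 2 (0.05 log units; within the scatter), a 1.1-fold higher number from compound 1 to compound 3 (0.03 log units; within the scatter) and a 1.0-fold lower number from compound 2 to compound 3 (0.02 log units; within the scatter). Compound 3 thus stands inside a flat group of three, separated from neither compound 1 nor compound 2 beyond the scatter.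

Compound 4 `CCC(C)(C)Cc1c[nH]c(CCc2ccc(-c3cccc(N)n3)cc2)n1` has not been measured. Its change from compound 3 is 6-aminopyridin-2-yl in place of pyrazin-2-yl on an aromatic carbon. All three measured steps bear on it, since each also exchanges the group on that same aromatic carbon, and each stayed within the scatter. On these data alone, none of those steps brought in a hydrogen-bond donor, so the weight of that part of the change is unknown from these data; the expectation rests on the flat response to the earlier exchanges. Compound 4 is expected to give 110 nM in this assay, with a range of 40 nM to 300 nM. This amounts to an expected step of a 1.0-fold higher number from compound 3 to compound 4 (0.01 log units; within the scatter), with no direction beyond the scatter.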

Compound 4, half-maximal effective concentration: 119 nM
Estimate against measurement, compound 4: 1.1-fold (0.03 log units) below, within the range that was stated.
By their numbers in this assay, from the lowest: compounds 1, 3, 2 and 4 (each within the scatter of the next).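

In this assay, among these compounds, 6-aminopyridin-2-yl, the only group in the set with a hydrogen-bond donor, sits on the aromatic carbon para to a large group and gives a 1.1-fold higher number from compound 3 to compound 4 (0.05 log units; within the scatter). The comparisons with the two azole-bearing compounds read the same way, with a 1.1-fold higher number from compound 2 to compound 4 (0.03 log units; within the scatter) and a 1.2-fold higher number from compound 1 to compound 4 (0.08 log units; within the scatter), so across these four compounds the read-out does not separate a group carrying a hydrogen-bond donor from groups without one, and the exchange of a ring with 2 hetero atoms for a larger, amine-bearing ring leaves all four numbers within the scatter of one another. There is no measurement at hand that would explain this flat response.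

Every group shown at this position is an aromatic ring, so it remains open whether a carboxylic acid, a plain primary amine or a saturated ring such as piperidine on the same aromatic carbon would also stay within the scatter. On these data alone, it is equally open whether this flat response holds with a longer chain in the shared core, since all four compounds carry the same one.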